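Dimethylamino for diethylamino on a chlorinated isatin core

The source may report more compounds than this note shows. Statements on the series, on what has been measured and on what is new or still open speak of the compounds shown alone.

Measured compounds:
compound 1, `Cc1ccc2nc(/N=C3\C(=O)N(CN(c4ccccc4)c4ccccc4)c4ccccc43)sc2c1`, 17700 nM
compound 2, `CN(C)CN1C(=O)C(=O)c2c(Br)cccc21`, 49000 nM
compound 3, `CCN(CC)CN1C(=O)C(=O)c2c(Cl)cccc21`, 28300 nM

Of the compounds shown here, three have been measured in a functional assay on MDA-MB-468 cells (Homo sapiens) for cytotoxicity, read by sulforhodamine B assay, with a stated time of 48 h; on this read-out lower numbers stand for stronger inhibition of growth and higher numbers for weaker inhibition of growth. Compound 3 gives 28300 nM, the second highest of the three numbers; its nearest neighbour is compound 1 at 17700 nM and its furthest is compound 2 at 49000 nM, and both gaps lie within the usual scatter, so the three cannot be ranked against one another.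

The unmeasured compound 4, `CN(C)CN1C(=O)C(=O)c2c(Cl)cccc21`, differs from compound 3 in one place: dimethylamino in place of diethylamino on a saturated chain carbon bound to an amide-type nitrogen in a ring. Compound 2 carries the same dimethylamino group on a brominated core, but it differs from compound 3 in two places, so it gives only a loose pointer.

Because compound 3 gives 28300 nM and all three measured numbers sit close together, the step from compound 3 to compound 4 is expected to be small, at most a mild weakening, estimated as a 1.3-fold higher number from compound 3 to compound 4 (0.13 log units; within the scatter). Compound 4 is therefore expected to give about 38000 nM, with a likely range from 15000 nM to 95000 nM.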

Compound 4, concentration for 50% growth inhibition: 107000 nM
Compound 4: the middle estimate sits 2.8-fold (0.45 log units) below what was measured; measured number outside the range, above it.
By their numbers in this assay, from the lowest: compounds 1, 3 and 2 (each within the scatter of the next, the first and the last beyond it); then compound 4.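

In this assay, for the compounds shown here, the amine on this saturated chain carbon bound to an amide-type nitrogen in a ring does count: dimethylamino in place of diethylamino gives a 3.8-fold higher number from compound 3 to compound 4 (0.58 log units; beyond the scatter) on the shared core, a step beyond the scatter that the earlier compounds, with no one-place pair among them, could not show. With dimethylamino held constant, the aromatic halogen counts as well, as chloro in place of bromo on an aromatic carbon gives a 2.2-fold higher number from compound 2 to compound 4 (0.34 log units; beyond the scatter), also beyond the scatter. Nothing shown here accounts for either step.

The compounds shown leave open whether the change from diethylamino to dimethylamino has the same size with bromo on the core. They also leave open how a ring amine such as piperidine or morpholine, or a longer chain such as dipropylamino, would read at this place.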